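Swapping the dichloroaryl tail of compound 1 for dimethyl

The compounds below may be only part of what the source reports. "The series", "measured", "known", "first", "only" and "open" are said of these compounds alone.

Three compounds sharing one core carry an aryl group on an oxygen on a saturated carbon and were tested in a functional assay on A549 cells (Homo sapiens) for antiproliferative activity, read by MTT assay, with a stated time of 72 h; a lower number here means a stronger inhibitor, a higher number a weaker inhibitor. Among the compounds with values here, compound 1 `NC1=NC2(CCOCC2)N(OCCCOc2cccc(Cl)c2Cl)C(N)=N1` gives 100 nM in this assay, the lowest of the two numbers known; its nearest neighbour is compound 2 `NC1=NC2(CCSCC2)N(OCCCOc2ccc(Cl)cc2)C(N)=N1`, which in this assay gives 580 nM. Compound 3 `NC1=NC2(CCSCC2)N(OCCCOc2cc(Cl)c(Cl)cc2Cl)C(N)=N1` sits at the limit of > 100000 nM in this assay, at which 1 of the 3 values shown sits, and its value there, > 100000 nM, is a limit rather than a number. Within the data shown here, the single measured one-place step, an at least 170-fold higher number from compound 2 to compound 3 (2.23 log units; beyond the scatter), shows how strongly the substitution pattern of the aryl group can move the result.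

Compound 4 `Cc1cc(C)cc(OCCCON2C(N)=NC(N)=NC23CCOCC3)c1` has not yet been measured in this assay. It differs from compound 1 in one place: 3,5-dimethylphenyl in place of 2,3-dichlorophenyl on an oxygen on a saturated carbon. Among the measured compounds shown here, no measured step exchanges chlorine for methyl on this ring, and the only step on the ring, an at least 170-fold higher number from compound 2 to compound 3 (2.23 log units; beyond the scatter), belongs to compounds whose core differs from that of compound 1 and ends at a limit, so it speaks only to the weight of the aryl pattern, not to the direction here. The account therefore expects a moderate loss, a 4.0-fold higher number from compound 1 to compound 4 (0.60 log units; beyond the scatter), with wide uncertainty. Compound 4 is estimated at 400 nM, between 80 nM and 5000 nM.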

Compound 4, half-maximal inhibitory concentration: 710 nM
Estimate against measurement, compound 4: 1.8-fold (0.25 log units) below, and the stated range covers the measured number.
By their numbers in this assay, from the lowest: compound 1; then compounds 2 and 4 (each within the scatter of the next). At a limit, above all of these: compound 3.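

Within the data shown here, with the shared core and the chain held fixed, 3,5-dimethylphenyl in place of 2,3-dichlorophenyl gives in this assay a 7.1-fold higher number from compound 1 to compound 4 (0.85 log units; beyond the scatter), the first step on this aryl group that is measured on the core of compound 1 and has a number at both ends. It shows that chlorine on the ring is not needed for a measured value on this core, since compound 4 carries none and still gives 710 nM, though the change costs activity relative to compound 1. Nothing shown here gives a cause for this step.

The step changes the kind of group and the places it occupies at once, so it cannot say which of the two accounts for the difference; 3,5-dichlorophenyl and 2,3-dimethylphenyl on the same core would separate them. The compounds shown also leave open how an unsubstituted phenyl, a methoxy group or an amine on the ring would read, and whether a longer chain on the oxygen would change the effect of the aryl pattern.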